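A few compounds are considered here, and "the series" means these few. Any claim that something is new, unique, unknown or untested is made for them only; others in the source may bear on it.

Compound 2 (`CC(C)(C)c1ccc(C(=O)N2CCC3(CC2)C(=O)N(CC(=O)NCCCCN)CN3c2ccccc2)cc1`) and compound 1 (`CC(C)(C)OC(=O)NC1CCCN(C(=O)CN2CN(c3ccccc3)C3(CCN(C(=O)c4ccc(C(C)(C)C)cc4)CC3)C2=O)C1`) share one core and differ only in the group hanging from the carbonyl on the methylene chain. In an assay on HEK293 cells for displacement of a labelled ligand from NPC1-like intracellular cholesterol transporter 1 (Homo sapiens) (on this read-out higher numbers stand for weaker inhibition and lower numbers for stronger inhibition), compound 1 gives 4200 nM, while compound 2 gives 14500 nM, the higher of the two numbers and separated from compound 1 by a gap beyond the usual scatter. Compound 3 (`CC(C)(C)c1ccc(C(=O)N2CCC3(CC2)C(=O)N(CC(=O)N2CCCC(C(N)=O)C2)CN3c2ccccc2)cc1`) is not yet measured; it carries 3-carbamoylpiperidin-1-yl in place of (4-aminobutyl)amino on a carbonyl carbon. For the measured compounds named here, with no measured step of this exact kind to lean on, the only guide is that compound 1, which also places a piperidine amide at that carbonyl, gives 4200 nM in this assay. Compound 3 is therefore expected to move toward a lower number, by a step of a 2.6-fold lower number from compound 2 to compound 3 (0.42 log units; beyond the scatter), in this assay. The estimate for compound 3 is 5500 nM, with a range from 1800 nM to 16000 nM.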

Compound 3, half-maximal inhibitory concentration: 16900 nM
Compound 3: the middle estimate sits 3.1-fold (0.49 log units) below what was measured, and the stated range ends below it.
By their numbers in this assay, from the lowest: compound 1; then compounds 2 and 3 (each within the scatter of the next).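

In this assay the change from (4-aminobutyl)amino to 3-carbamoylpiperidin-1-yl on a carbonyl carbon gives a 1.2-fold higher number from compound 2 to compound 3 (0.07 log units; within the scatter) and so shows that a piperidine amide at this carbonyl does not by itself bring the number to that of compound 1. With the piperidine amide kept, carbamoyl in place of (tert-butoxycarbonyl)amino on a saturated ring carbon gives a 4.0-fold higher number from compound 1 to compound 3 (0.60 log units; beyond the scatter) and so places the modest difference seen here in the group on the ring. Nothing measured alongside these compounds accounts for either step.

The compounds shown leave open whether an amine, a carboxylic acid or a longer alkyl chain on that ring carbon would stand nearer compound 1 or compound 3. They also leave open where a plain piperidine, with no group on the ring, would fall.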